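Trifluoromethyl for chloro on a shared bicyclic core

The source may report more compounds than this note shows. Statements on the series, on what has been measured and on what is new or still open speak of the compounds shown alone.

Of the compounds shown here, three from one series have been measured so far, and a fourth awaits measurement. Compound 1 `NC(=S)N/N=C1/C(=O)N(CN2CCN(c3ccnc4cc(Cl)ccc34)CC2)c2cccc(Cl)c21` is the starting point: in a functional assay on MCF7 cells (Homo sapiens) for cytotoxicity, read by sulforhodamine B assay, with a stated time of 48 h (a lower number here means a stronger inhibitor of growth, a higher number a weaker inhibitor of growth), compound 1 gives 57500 nM. Compound 3 `NC(=S)N/N=C1/C(=O)N(CN2CCN(c3ccnc4cc(C(F)(F)F)ccc34)CC2)c2cccc(Cl)c21` differs from compound 1 only by trifluoromethyl in place of chloro on an aromatic carbon, and that single change produced a 2.7-fold lower number from compound 1 to compound 3 (0.43 log units; beyond the scatter). Compound 2 `NC(=S)N/N=C1/C(=O)N(CN2CCN(c3ccnc4cc(Cl)ccc34)CC2)c2cc(Cl)ccc21` carries the same atoms as compound 1 joined differently; how its core differs from the core of compound 1 is not broken down here. In this assay compound 2 gives 22500 nM, while compound 3 gives 21600 nM, two values within the usual scatter of each other.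

Compound 4 `NC(=S)N/N=C1/C(=O)N(CN2CCN(c3ccnc4cc(C(F)(F)F)ccc34)CC2)c2cc(Cl)ccc21` stands to compound 2 exactly as compound 3 stands to compound 1: the difference is trifluoromethyl in place of chloro on an aromatic carbon, at a place described in the same words, so it is the same change made on a second core. Because the earlier step was a 2.7-fold lower number from compound 1 to compound 3 (0.43 log units; beyond the scatter), a similar step is expected, though with caution since it rests on one pair: the expected step is a 2.3-fold lower number from compound 2 to compound 4 (0.35 log units; beyond the scatter). Compound 4 is therefore estimated at 10000 nM in this assay, most likely between 4000 nM and 25000 nM.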

Compound 4, concentration for 50% growth inhibition: 24600 nM
Estimate against measurement, compound 4: 2.5-fold (0.39 log units) below; the range from low to high includes it.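

Carried to the second core, the swap of chloro for trifluoromethyl did not repeat what it did on the first: in this assay the new step is a 1.1-fold higher number from compound 2 to compound 4 (0.04 log units; within the scatter), so the number stays within the usual scatter. Set side by side, the two steps differ by more than chance repeats would explain: the same change on two cores in this assay, a 2.7-fold lower number (0.43 log units; beyond the scatter) from compound 1 to compound 3 and a 1.1-fold higher number (0.04 log units; within the scatter) from compound 2 to compound 4, 2.9-fold (0.46 log units) apart, beyond the scatter of two such steps This shows that, in this series, the result of this change on one core could not simply be carried over to the other, though it does not show why the two cores part ways, and with one pair on each core it says nothing about how the change would behave on any further core.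

The compounds shown hold only chloro or trifluoromethyl at this place, so it stays open how a nitrile, a methoxy group or an amine there would fare on each core. Going by these compounds, it also stays open whether such groups would show the same split between the two cores.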